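This account rests on a few compounds, and the source may have more. Where it says the series, first, only, none or still open, it means among the compounds named here.

Measured so far in an assay on HEK293 cells for displacement of a labelled ligand from 5-hydroxytryptamine receptor 6 (Homo sapiens), read by radioligand binding, with a stated time of 60 min, tested at 100 nM; a lower number here means less inhibition, a higher number more inhibition at the concentration tested (going by the name of the read-out):
- compound 1 `CN(C)CCn1c(=O)sc2cc(S(=O)(=O)c3ccccc3)ccc21`: 16%
- compound 2 `O=c1sc2cc(S(=O)(=O)c3ccccc3)ccc2n1CCN1CCCCC1`: 11%
- compound 3 `O=c1sc2cc(NS(=O)(=O)c3ccc4ccccc4c3)ccc2n1CCN1CCCC1`: 0%

Compound 2 stands second highest of the three numbers in this assay. Its nearest neighbour is compound 1, and the step of a number 5 percentage points lower from compound 1 to compound 2 (within the scatter) is within the scatter, so the two are not distinguishable. Among the measured compounds shown here, compound 3 gives 0%, a lower number beyond the scatter, but it differs from compound 2 in more than one place, so no single step can be drawn from it.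

Compound 4 `CN(c1ccccc1)S(=O)(=O)c1ccc2c(c1)sc(=O)n2CCN1CCCCC1` is compound 2 with one change: methyl(phenyl)amino in place of phenyl on a sulfonyl sulfur. For the measured compounds named here, the only measured single step, from compound 1 to compound 2, concerns the amine on the chain, not the sulfonyl sulfur, so it says nothing about this change. Nothing measured here bears directly on it, and the expectation can only rest on compound 2 itself. The step of a number 1 percentage points lower from compound 2 to compound 4 (within the scatter) is therefore expected to stay within the scatter. Compound 4 is estimated at 10%, ranging from 0% to 25%.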

Compound 4, a percentage reported as inhibition, at one concentration (the size of the read-out at that concentration, not a potency): 0%
Beside the measured number, compound 4's estimate is 10 percentage points above it, within the range that was stated.
By their numbers in this assay, from the lowest: compounds 3 and 4 (each within the scatter of the next); then compounds 2 and 1 (each within the scatter of the next).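

In this assay, among the compounds shown here, the sulfonyl sulfur now has a step of its own, a number 11 percentage points lower from compound 2 to compound 4 (beyond the scatter), whereas the only earlier single step, a number 5 percentage points lower from compound 1 to compound 2 (within the scatter), concerned the amine on the chain and stayed within the scatter. This position therefore responds to a change, if modestly: methyl(phenyl)amino, with 8 heavy atoms, keeps the six-membered aromatic ring of phenyl, with 6 heavy atoms, yet the inhibition at the tested concentration is lower. Nothing available here explains this difference.

The compounds shown leave open whether the lower number goes with the added nitrogen or with its methyl, a question that phenylamino on the sulfonyl sulfur could help to settle. They also leave open whether the same change would give a similar step with dimethylamino on the chain.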